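The source may hold more compounds than are shown below. What is called first, only, known or untested is meant among the compounds shown, and "the series" means these compounds.

Compound 2, with the structure `CN1CCN(c2nc(-c3ccc(C(=O)NO)cc3)nc3ccccc23)CC1`, gives 89.4% in an assay on isolated protein for inhibition of protein deacetylase HDAC6 (Homo sapiens), tested at 0.5 uM; a higher number here means more inhibition at the concentration tested (going by the name of the read-out), a lower number less inhibition; this is the higher of the two numbers measured, and compound 1, with the structure `O=C(NO)c1ccc(-c2nc(N3CCCCC3)c3ccccc3n2)cc1`, gives 66.4% in this assay. Compound 3, with the structure `O=C(NO)c1ccc(-c2nc(N3CCC(F)(F)CC3)c3ccccc3n2)cc1`, has not yet been measured. Its difference from compound 2 is 4,4-difluoropiperidin-1-yl in place of 4-methylpiperazin-1-yl on an aromatic carbon. Among the compounds with values here, one measured step bears on this change: a number 23 percentage points higher from compound 1 to compound 2 (beyond the scatter). That step moved from piperidin-1-yl to 4-methylpiperazin-1-yl, whereas the new change moves back to a ring with one hetero atom, now carrying two fluorines. Within the data shown here, no measured step shows what the two fluorines do. The expectation is therefore a step of a number 19.4 percentage points lower from compound 2 to compound 3 (beyond the scatter), roughly reversing part of the gain seen from compound 1 to compound 2. Compound 3 is estimated at 70%, within a range from 50% to 88%.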

Compound 3, a percentage reported as inhibition, at one concentration (the size of the read-out at that concentration, not a potency): 71.7%
For compound 3 the middle estimate is 1.7 percentage points below the measured one; the range from low to high includes it.
By their numbers in this assay, from the lowest: compounds 1 and 3 (each within the scatter of the next); then compound 2.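

In this assay, replacing 4-methylpiperazin-1-yl with 4,4-difluoropiperidin-1-yl at this position gives a number 17.7 percentage points lower from compound 2 to compound 3 (beyond the scatter), so a ring with one hetero atom does not keep the higher number even when it carries two fluorines. Replacing piperidin-1-yl with 4,4-difluoropiperidin-1-yl gives a number 5.3 percentage points higher from compound 1 to compound 3 (within the scatter), so the two fluorines cannot be told apart from the plain ring in this read-out, and among these three rings only 4-methylpiperazin-1-yl stands out. No measured evidence here explains these differences.

On these data alone, it remains open whether the higher number goes with the second ring nitrogen or with the methyl on it. A piperazin-1-yl ring without the methyl and a morpholin-4-yl ring, which has an oxygen in place of that nitrogen, would help separate the two.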